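A few compounds are considered here, and "the series" means these few. Any claim that something is new, unique, unknown or untested is made for them only; others in the source may bear on it.

Measured in a physicochemical assay for solubility, in phosphate buffer, measured as kinetic solubility, with a stated time of 24 h, at pH 6.5; on this read-out lower numbers stand for lower solubility and higher numbers for higher solubility:
- compound 1 `Cc1ccc(NC(=O)c2cc(Oc3ccc(S(C)(=O)=O)cc3)cc(OC(C)C)c2)nc1`: 1400 nM
- compound 2 `CC(C)Oc1cc(Oc2ccc(S(C)(=O)=O)cc2)cc(-c2cncc(=O)[nH]2)c1`: 118000 nM
- compound 3 `Cc1cnc(-c2cc(Oc3ccc(S(C)(=O)=O)cc3)cc(OC(C)C)c2)[nH]c1=O`: 1900 nM

Compound 3 stands level with compound 1, with a step of a 1.4-fold higher number from compound 1 to compound 3 (0.13 log units; within the scatter), which lies within the scatter. Compound 2 is well clear of both. The step of an 84-fold higher number from compound 1 to compound 2 (1.93 log units; beyond the scatter) is large and beyond the scatter, as is a 62-fold lower number from compound 2 to compound 3 (1.79 log units; beyond the scatter).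

The next structure is compound 4 `CCc1cnc(-c2cc(Oc3ccc(S(C)(=O)=O)cc3)cc(OC(C)C)c2)[nH]c1=O`. The change is methyl in place of hydrogen on a saturated chain carbon bound to an aromatic carbon, and the same difference reads methyl to ethyl.

Among the measured compounds shown here, no measured step is this exact change, so the evidence is indirect. All three measured steps exchange a whole ring-bearing group, which is a far larger edit than this one. Those exchanges also point both ways. The step of a 62-fold lower number from compound 2 to compound 3 (1.79 log units; beyond the scatter) is large, yet a 1.4-fold higher number from compound 1 to compound 3 (0.13 log units; within the scatter) stays within the scatter. Neither size carries over directly to a chain extension.

In this assay, no step beyond the scatter is therefore expected, with at most a slight drift to a lower number. The expected step is a 1.4-fold lower number from compound 3 to compound 4 (0.13 log units; within the scatter). For compound 4 the estimate is 1400 nM, with an expected range of 400 nM to 4000 nM.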

Compound 4, solubility: 5700 nM
For compound 4 the middle estimate is 4.1-fold (0.61 log units) below the measured one, and the stated range ends below it.
By their numbers in this assay, from the lowest: compounds 1 and 3 (each within the scatter of the next); then compound 4; then compound 2.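

In this assay, among the compounds shown here, the step of a 3.0-fold higher number from compound 3 to compound 4 (0.48 log units; beyond the scatter) is the first measured edit that leaves the ring-bearing group in place and changes only a chain on it; methyl in place of hydrogen on this saturated chain carbon bound to an aromatic carbon gives a modest move to a higher number, beyond the scatter. The same edit separates the series where it previously did not: the step of a 4.1-fold higher number from compound 1 to compound 4 (0.61 log units; beyond the scatter) is beyond the scatter, whereas compound 3 and compound 1 stand within the scatter of each other, but compound 2 stays well clear, with a 21-fold lower number from compound 2 to compound 4 (1.32 log units; beyond the scatter) still large. Nothing in the data shown accounts for the direction or size of this step.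

The compounds shown leave open whether the rise with methyl to ethyl continues, levels off or reverses with a longer chain such as propyl, or with a branched isopropyl group at the same place. Also open, going by these compounds, is how an amine, a hydroxyl or a carboxylic acid at the end of this chain would read in this assay and whether any such group would close the remaining gap to compound 2.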